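Cyclohexene carboxamides: amide head-group swap toward a hydroxamic acid

The compounds below may be only part of what the source reports. "The series", "measured", "known", "first", "only" and "open" are said of these compounds alone.

Measured compounds:
- compound 1, `COC(=O)CCNC(=O)[C@H]1CC=C(CCC=C(C)C)C[C@@H]1c1ccccc1`, gives 3100 nM in an assay on isolated protein for inhibition of Apoptosis regulator Bcl-2 (Homo sapiens), read by fluorescence polarization, with stated times of 5 min and 10 min; on this read-out higher numbers stand for weaker inhibition and lower numbers for stronger inhibition.
- compound 2, `CC(C)=CCCC1=CC[C@@H](C(=O)NCCC(=O)O)[C@H](c2ccccc2)C1`, reaches only the limit > 23000 nM in this assay; that is a limit of the assay, not a number.

Among the measured compounds shown here, compound 1 carries the only real number in this assay so far; the other entry, for compound 2, is the limit (the limit of > 23000 nM in this assay, at which 1 of the 2 values shown sits), so no measured step can be read.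

Compound 3, `CC(C)=CCCC1=CC[C@H](C(=O)N(C)O)[C@@H](c2ccccc2)C1`, has not been measured. It differs from compound 1 in one place: hydroxy(methyl)amino in place of (2-(methoxycarbonyl)ethyl)amino on a carbonyl carbon. The methyl ester and its two-carbon linker are gone, and a smaller head with one hydrogen-bond donor and one acceptor sits on the carbonyl carbon.

For the measured compounds named here, with no measured step to lean on, only a modest expectation can be framed. The step from compound 1 is expected to be small and toward weaker inhibition, on the order of a 1.6-fold higher number from compound 1 to compound 3 (0.21 log units; within the scatter), and it may not exceed the usual scatter. Compound 3 is therefore estimated at 5000 nM in this assay, within a range of 1500 nM to 20000 nM.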

Compound 3, inhibition constant: 2100 nM
Compound 3: middle estimate off by 2.4-fold (0.38 log units), on the high side; the range from low to high includes it.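

In this assay, among the compounds shown here, hydroxy(methyl)amino in place of (2-(methoxycarbonyl)ethyl)amino on a carbonyl carbon gives a 1.5-fold lower number from compound 1 to compound 3 (0.17 log units; within the scatter), the first step that can be read. The methyl ester and its two-carbon linker can therefore leave this position, with 7 heavy atoms replaced by 3, without a change beyond the scatter, and compound 3 gives 2100 nM. Compound 2 remains a limit and not a number, and steps that involve it cannot be read: the limit of > 23000 nM in this assay, at which 1 of the 3 values shown sits.

The compounds shown leave open which part of the hydroxy(methyl)amino head matters, as a hydroxyamino group without the methyl, or a methoxy(methyl)amino or dimethylamino group on the same carbonyl carbon, would separate the contributions of the hydroxy and the methyl. Also open, going by these compounds, is how far the read-out at this position would follow a different head altogether, such as a simple primary amide or a longer chain ending in a methyl ester, on the shared core.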